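This account rests on a few compounds, and the source may have more. Where it says the series, first, only, none or still open, it means among the compounds named here.

Measured compounds:
Compound 1 `COc1nc2ccc(Br)cc2cc1C(c1ccccc1)n1cc(CCCO)nn1`: 14.7%
Compound 2 `COc1nc2ccc(Br)cc2cc1C(c1ccccc1)n1cc(-c2ccccc2C(F)(F)F)nn1`: 17.4%

Of the compounds shown here, two sharing one core have been tested in an ADME assay on PC-3 cells (Homo sapiens) for cytotoxicity, read by sulforhodamine B assay, with a stated time of 48 h, tested at 10 uM; a lower number here means less inhibition, a higher number more inhibition at the concentration tested (going by the name of the read-out). Compound 1 gives 14.7% in this assay, and compound 2 gives 17.4%. Among the compounds with values here, compound 2 thus carries the higher of the two numbers, but its nearest neighbour is compound 1 and the one measured step, a number 2.7 percentage points higher from compound 1 to compound 2 (within the scatter), stays within the scatter, so the two values cannot be told apart.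

Compound 3 `COc1nc2ccc(Br)cc2cc1C(c1ccccc1)n1cc(C2CC2)nn1` has not yet been measured. It differs from compound 2 at the same position that was altered in the measured step: cyclopropyl in place of 2-(trifluoromethyl)phenyl on an aromatic carbon. Within the data shown here, the only step that bears on this change is the one from compound 1 to compound 2, which swapped a short hydroxy-bearing chain for a substituted ring at this carbon and left the read-out essentially unchanged. That step gives no hint that this position drives the cytotoxicity read-out, so compound 3 is expected to show a number 2.4 percentage points lower from compound 2 to compound 3 (within the scatter), no change beyond the scatter. Compound 3 is therefore estimated at 15%, within a range of 4% to 28%.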

Compound 3, a percentage reported as inhibition, at one concentration (the size of the read-out at that concentration, not a potency): 22.6%
Beside the measured number, compound 3's estimate is 7.6 percentage points below it; measured number inside the range.
By their numbers in this assay, from the lowest: compounds 1, 2 and 3 (each within the scatter of the next).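

In this assay, cyclopropyl in place of 2-(trifluoromethyl)phenyl gives a number 5.2 percentage points higher from compound 2 to compound 3 (within the scatter) and cyclopropyl in place of 3-hydroxypropyl gives a number 7.9 percentage points higher from compound 1 to compound 3 (within the scatter) on the same aromatic carbon. This carbon of the five-membered aromatic ring with 3 nitrogen has now carried a chain, an aromatic ring and a three-membered non-aromatic ring, and going from a group of 10 heavy atoms to one of 3 heavy atoms leaves a difference that cannot be told apart from the scatter, so none of the three compounds stands apart from the other two. Nothing available offers an explanation for these numbers or for how close together they lie.

The compounds shown leave open whether an amine, a carboxylic acid or a longer chain on this carbon would move the read-out beyond the scatter. They also leave open whether a change elsewhere on the shared core would have any larger effect on the read-out than the changes seen at this one position.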